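Aryl for alkyl on the shared core: an untested step

The source may report more compounds than this note shows. Statements on the series, on what has been measured and on what is new or still open speak of the compounds shown alone.

Measured so far in a functional assay on DU-145 cells (Homo sapiens) for cytotoxicity, read by sulforhodamine B assay, with a stated time of 2 days, tested at 100 uM; a lower number here means less inhibition, a higher number more inhibition at the concentration tested (going by the name of the read-out):
compound 1 `CCCc1n[nH]c2c(=O)n(NC(=O)c3ccncc3)c(-c3cccc(OC)c3)nc12` gives 9.13%
compound 2 `O=C(Nn1c(-c2cccc([N+](=O)[O-])c2)nc2c(-c3ccc(F)cc3)n[nH]c2c1=O)c1cccnc1` gives 24.9%
compound 3 `CCCc1n[nH]c2c(=O)n(NC(=O)c3ccccc3)c(-c3cccc(OC)c3)nc12` gives 23.6%

Compound 3 stands second highest of the three numbers. Its nearest neighbour is compound 2, whose value lies within the scatter of that of compound 3, so the two cannot be told apart. For the measured compounds named here, compound 1 lies lowest; the only measured step, a number 14.5 percentage points higher from compound 1 to compound 3 (beyond the scatter), is a modest rise that comes from changing the group on the carbonyl carbon.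

Compound 4 `COc1cccc(-c2nc3c(-c4cccc(Cl)c4)n[nH]c3c(=O)n2NC(=O)c2ccccc2)c1` has not been measured. It differs from compound 3 in one place: 3-chlorophenyl in place of propyl on an aromatic carbon. Going by the values given here, no measured step touches this position, so the only guide is that compound 2, which carries a different aromatic ring on that carbon alongside other changes, gives a value within the scatter of compound 3.

For compound 4, then, no step beyond the scatter is expected, and a number 3.4 percentage points higher from compound 3 to compound 4 (within the scatter) is the estimated change. The expected value for compound 4 is 27%, with a range from 10% to 50%.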

Compound 4, a percentage reported as inhibition, at one concentration (the size of the read-out at that concentration, not a potency): 93.5%
The estimate for compound 4 lay 66.5 percentage points below the measured number; measured number above the stated range.
By their numbers in this assay, from the lowest: compound 1; then compounds 3 and 2 (each within the scatter of the next); then compound 4.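

Swapping propyl for 3-chlorophenyl on this aromatic carbon of the five-membered ring gives a number 69.9 percentage points higher from compound 3 to compound 4 (beyond the scatter) in this assay and is the first measured change at this position. For the compounds shown here, it shows that this carbon can have a large effect on the read-out, whereas the only earlier step, at the carbonyl carbon, was modest. Nothing available explains why the number rises so sharply at this position, so the result records the size of the change but not its cause.

The compounds shown do not separate the contribution of the added ring from that of its chlorine, so an unsubstituted phenyl at this carbon would be the direct test. Also open, as far as these compounds go, is how a longer alkyl chain such as hexyl, or an amine, would behave at the same carbon.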